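The source may report more compounds than this note shows. Statements on the series, on what has been measured and on what is new or still open speak of the compounds shown alone.

Working notes on the series. Compound 1 `C=CC[C@H]1C[C@]2([C@@H](C)Cc3ccc(OC)c(OC)c3)OCOC2=CC1=O` is the reference point. In a functional assay on M14 cells (Homo sapiens) for antiproliferative activity, with a stated time of 72 h (a lower number here means a stronger inhibitor, a higher number a weaker inhibitor), compound 1 gives 110 nM, the lowest of the two numbers available; the nearest number belongs to compound 3 `C=CC[C@H]1C[C@]2(CCc3ccc(OC)c(OC)c3)OCOC2=CC1=O`, which in this assay gives 2000 nM. Compound 2 `C=CC[C@@H]1C[C@]2([C@@H](C)Cc3ccc(OC)c(OC)c3)OCOC2=CC1=O` gives only a limit in this assay, > 4000 nM. Both measured steps start from compound 1: an at least 36-fold higher number from compound 1 to compound 2 (1.56 log units; beyond the scatter), where the two compounds differ only in configuration as drawn, and an 18-fold higher number from compound 1 to compound 3 (1.26 log units; beyond the scatter), hydrogen in place of methyl on a saturated chain carbon. Both were large, and both concern the saturated part of the shared core and its side chain; neither touches the aromatic ring.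

Compound 4 `C=CC[C@H]1C[C@]2([C@@H](C)Cc3ccc(OC)c(C(N)=O)c3)OCOC2=CC1=O` is the next compound: carbamoyl in place of methoxy on an aromatic carbon. Going by the values given here, no measured step bears on this change, since the methoxy groups on the aromatic ring are unchanged across compounds 1, 2 and 3, so nothing shows how they contribute. The expectation is made without a direct precedent and with a wide range. A modest loss is expected, a 2.7-fold higher number from compound 1 to compound 4 (0.44 log units; beyond the scatter), with the configuration and chain methyl of compound 1 kept intact. Compound 4 is thus estimated at 300 nM in this assay, between 80 nM and 1500 nM.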

Compound 4, half-maximal inhibitory concentration: 12 nM
For compound 4 the middle estimate is 25-fold (1.40 log units) above the measured one, outside the stated range (below it).
By their numbers in this assay, from the lowest: compound 4; then compound 1; then compound 3. At a limit, above all of these: compound 2.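

The aromatic ring, unchanged across compound 1, compound 2 and compound 3, proves to matter: in this assay there is a 9.2-fold lower number from compound 1 to compound 4 (0.96 log units; beyond the scatter) with carbamoyl in place of methoxy, on an aromatic carbon ortho to a methoxy group. This methoxy is therefore not needed for activity here, and compound 4, at 12 nM, holds the lowest number shown, so this position can take a group of one more heavy atom that, as counted, brings a hydrogen-bond donor where methoxy has none. The change is a single exchange, so it does not separate the contribution of the amide hydrogens from that of the carbonyl, and nothing available on these compounds accounts for the drop in the number.

Open, from the compounds shown here alone, is whether a nitrile, a carboxylic acid or an N-methyl carboxamide at this position would give a similar number, which would show how much depends on the amide hydrogens. Also open, going by these compounds, are what the same exchange does at the remaining methoxy group and whether the gain persists with the opposite configuration or without the chain methyl.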